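Swapping one small heteroaryl amide for another

The compounds below may be only part of what the source reports. "The series", "measured", "known", "first", "only" and "open" are said of these compounds alone.

Measured so far:
Compound 1 `O=C(COc1ccc2c(=O)ccoc2c1)Nc1cccc(NC(=O)c2ccc(F)cc2)c1` gives 129 nM in an assay on isolated protein for inhibition of Rho-associated protein kinase 1 (Homo sapiens), read by scintillation counting, radiometric assay and 33P incorporation, with a stated time of 40 min, in the presence of a further agent that is not named here; a lower number here means a stronger inhibitor, a higher number a weaker inhibitor.
Compound 2 `COC(=O)c1ccc(C(=O)Nc2cccc(NC(=O)COc3ccc4c(=O)ccoc4c3)c2)cc1` gives 72 nM in this assay.
Compound 3 `Cc1nc(C(=O)Nc2cccc(NC(=O)COc3ccc4c(=O)ccoc4c3)c2)cs1` gives 473 nM in this assay.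

All three share the same core and differ only in the group attached to the carbonyl carbon of the second amide. Compound 3 has the highest number of the three: its nearest neighbour is compound 1 (a 3.7-fold higher number from compound 1 to compound 3 (0.56 log units; beyond the scatter)), and its furthest is compound 2 (a 6.6-fold higher number from compound 2 to compound 3 (0.82 log units; beyond the scatter)). Both of those steps replaced a substituted phenyl with a one five-membered aromatic ring with 2 hetero atoms and both pushed the number up beyond the scatter.

Compound 4 `Cc1cc(C(=O)Nc2cccc(NC(=O)COc3ccc4c(=O)ccoc4c3)c2)no1` is the next step from compound 3: 5-methyl-1,2-oxazol-3-yl in place of 2-methyl-1,3-thiazol-4-yl on a carbonyl carbon. Among the measured compounds shown here, no measured pair tests this exact exchange of one such small ring for another; the only steps on record concern the move from a phenyl to such a ring, not between two of them. With nothing pointing either way, the expectation for this assay is a step of about a 1.1-fold higher number from compound 3 to compound 4 (0.02 log units; within the scatter), that is, none beyond the scatter. Compound 4 is therefore estimated at 500 nM, with a range from 200 nM to 1300 nM.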

Compound 4, half-maximal inhibitory concentration: 68 nM
Compound 4: middle estimate off by 7.4-fold (0.87 log units), on the high side; measured number below the stated range.
By their numbers in this assay, from the lowest: compounds 4, 2 and 1 (each within the scatter of the next); then compound 3.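

This position is far from indifferent to which small ring it carries. In this assay the exchange gives a 7.0-fold lower number from compound 3 to compound 4 (0.84 log units; beyond the scatter), even though the two rings have the same heavy-atom, donor and acceptor counts and both are five-membered aromatic rings with 2 hetero atoms. Compound 4 also goes against the impression left by compound 3 that a small ring on this carbonyl carbon pushes the number up compared with a substituted phenyl, since the steps to it, a 1.1-fold lower number from compound 2 to compound 4 (0.02 log units; within the scatter) and a 1.9-fold lower number from compound 1 to compound 4 (0.28 log units; within the scatter), both lie within the scatter.

No measurement shown here explains why these two rings differ so much. The two rings differ at once in oxygen against sulfur and in how their atoms are arranged, so the compounds shown cannot assign the step to either difference, and how a 1,2-oxazol-3-yl without the methyl, or one carrying an amine in its place, would behave remains open.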